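Hydroxyl position on the benzyl group in a purine series

The source may report more compounds than this note shows. Statements on the series, on what has been measured and on what is new or still open speak of the compounds shown alone.

Of the compounds shown here, three share a core and have been measured in a functional assay on K562 cells (Homo sapiens) for cytotoxicity; on this read-out lower numbers stand for stronger inhibition and higher numbers for weaker inhibition. Compound 1 `CC(C)n1cnc2c(NCc3ccc(O)cc3)nc(NCCCO)nc21` gives 57000 nM, and compound 2 `CC(C)n1cnc2c(NCc3cccc(O)c3)nc(NCCCO)nc21` gives 56000 nM. Compound 3 `CC(C)C(CO)Nc1nc(NCc2cccc(O)c2)c2ncn(C(C)C)c2n1` gives 16100 nM, the lowest of the three numbers.

Two changes connect them. Compound 2 differs from compound 1 by 4-hydroxyphenyl in place of 3-hydroxyphenyl on a saturated chain carbon bound to a nitrogen on an aromatic ring, and this step, a 1.0-fold higher number from compound 2 to compound 1 (0.01 log units; within the scatter), leaves the two values within the scatter of each other. Compound 3 differs from compound 2 in its core, by 1-(hydroxymethyl)-2-methylpropyl in place of 3-hydroxypropyl on a nitrogen on an aromatic ring, and this step, a 3.5-fold lower number from compound 2 to compound 3 (0.54 log units; beyond the scatter), is a modest one beyond the scatter.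

Compound 4 `CC(C)C(CO)Nc1nc(NCc2ccc(O)cc2)c2ncn(C(C)C)c2n1` has not yet been measured in this assay. It differs from compound 3 by 4-hydroxyphenyl in place of 3-hydroxyphenyl on a saturated chain carbon bound to a nitrogen on an aromatic ring. For the measured compounds named here, this is the same change as the one from compound 2 to compound 1, made here on the core of compound 3 rather than on the core of compound 2; the place of the change reads the same in both pairs.

Going by the values given here, since the one earlier instance of this change, a 1.0-fold higher number from compound 2 to compound 1 (0.01 log units; within the scatter), stayed within the scatter, the expected step from compound 3 to compound 4 is a 1.0-fold lower number from compound 3 to compound 4 (0.00 log units; within the scatter), that is, essentially no movement. On that basis, compound 4 is estimated at 16000 nM in this assay, with a likely range from 8000 nM to 32000 nM, resting on a single precedent only.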

Compound 4, half-maximal inhibitory concentration: 14800 nM
Estimate against measurement, compound 4: 1.1-fold (0.03 log units) above, within the range that was stated.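

In this assay, putting 4-hydroxyphenyl in place of 3-hydroxyphenyl on the core that carries the 1-(hydroxymethyl)-2-methylpropyl chain gives a 1.1-fold lower number from compound 3 to compound 4 (0.04 log units; within the scatter), and this step agrees with the one on the core that carries the 3-hydroxypropyl chain: the same change on two cores in this assay, a 1.0-fold higher number (0.01 log units; within the scatter) from compound 2 to compound 1 and a 1.1-fold lower number (0.04 log units; within the scatter) from compound 3 to compound 4, 1.1-fold (0.04 log units) apart, within the scatter of two such steps

The chain exchange, 1-(hydroxymethyl)-2-methylpropyl in place of 3-hydroxypropyl, now read with the 4-hydroxyphenyl group in place, gives a 3.9-fold lower number from compound 1 to compound 4 (0.59 log units; beyond the scatter), and it agrees with the same exchange read with the 3-hydroxyphenyl group: the same change on two cores in this assay, a 3.5-fold lower number (0.54 log units; beyond the scatter) from compound 2 to compound 3 and a 3.9-fold lower number (0.59 log units; beyond the scatter) from compound 1 to compound 4, 1.1-fold (0.04 log units) apart, within the scatter of two such steps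

Across these four compounds, then, the hydroxyl exchange carried over from one core to the other without a visible shift, and the chain exchange kept its size whichever hydroxyphenyl group was present, but this rests on only two cores, one pair for each, and one cell line, so it shows neither a general rule for the series nor why the values behave this way.

As far as these compounds go, what a plain benzyl group, or a methoxy or amino group in place of the hydroxyl, would do on either core remains open. So does whether the agreement would hold with a longer chain or a carboxylic acid in place of the hydroxyalkyl chains.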